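The source may hold more compounds than are shown below. What is called first, only, known or untested is meant among the compounds shown, and "the series" means these compounds.

Compound 1 `Cc1ccccc1-n1nncc1CN1C(=O)C2(C(C#N)=C(N)Oc3c2c2nc4ccccc4nc2c2ccccc32)c2ccccc21` carries 2-methylphenyl on the aromatic nitrogen. In an ADME assay on HUVEC cells (Homo sapiens) for antiproliferative activity, read by MTT assay, with a stated time of 48 h (on this read-out higher numbers stand for weaker inhibition and lower numbers for stronger inhibition), compound 1 gives only a limit, > 50000 nM. Compound 2 `N#CC1=C(N)Oc2c(c3nc4ccccc4nc3c3ccccc23)C12C(=O)N(Cc1cnnn1-c1ccc(Cl)cc1)c1ccccc12` carries 4-chlorophenyl at the same nitrogen. In this assay compound 2 likewise gives only a limit, > 50000 nM. The step that the two limits leave unreadable from compound 1 to compound 2 has no readable size because of the limit of > 50000 nM in this assay, at which 2 of the 2 values shown sit. Compound 3 `Cc1cc(C)cc(-n2nncc2CN2C(=O)C3(C(C#N)=C(N)Oc4c3c3nc5ccccc5nc3c3ccccc43)c3ccccc32)c1` differs from compound 2 by 3,5-dimethylphenyl in place of 4-chlorophenyl on an aromatic nitrogen. Going by the values given here, the single measured step at this position bears on the change but fixes no size, so no step beyond the scatter is expected in this assay. Compound 3 is estimated at 80000 nM, between 30000 nM and 300000 nM. The step that the limit leaves unreadable from compound 2 to compound 3 is thus expected to stay within the scatter.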

Compound 3, half-maximal inhibitory concentration: > 50000 nM
Compound 3: only a limit was reported; the forecaster's own chance of this, stated with the estimate: 85%; the middle value lies beyond the limit too.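

No new step can be read among compound 1, compound 2 and compound 3, because their values are limits and not numbers: the limit of > 50000 nM in this assay, at which 3 of the 3 values shown sit. As far as these compounds go, whether any of the three groups on the aromatic nitrogen differs from another in this assay stays open.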